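The source may report more compounds than this note shows. Statements on the series, on what has been measured and on what is new or still open speak of the compounds shown alone.

Working notes on the series. Of the compounds shown here, three have been measured in an assay on HEK293 cells for displacement of a labelled ligand from 5-hydroxytryptamine receptor 7 (Homo sapiens), read by radioligand binding; a lower number here means a stronger inhibitor, a higher number a weaker inhibitor. Compound 1 `O=c1n(CCCCCCN2CCN(c3cccc4ccccc34)CC2)nc2ccccn12` gives 186 nM. Compound 2 `O=C(NCCCCCCn1nc2ccccn2c1=O)N1CCN(c2cccc(Cl)c2)CC1` gives 462 nM in this assay, and compound 3 `NS(=O)(=O)NCCCCCCN1CCN(c2cccc(Cl)c2)CC1` gives 167 nM.

Among these three numbers compound 1 has the second highest. Its value and that of compound 3 lie within the usual scatter of each other, so nothing separates the two. For the measured compounds named here, compound 2 shows the higher number, and the gap between compound 2 and compound 1 is beyond the scatter; no single-point step between the two is defined, since they differ in more than one place.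

Compound 4 `O=c1n(CCCCCCN2CCN(c3cccc4cccnc34)CC2)nc2ccccn12` is not yet measured. It differs from compound 1 in one place: quinolin-8-yl in place of naphthalen-1-yl on an amine nitrogen in a ring. The shared core and the six-carbon chain linking it to the ring amine are unchanged. Going by the values given here, no measured pair in the set isolates this kind of change, so there is no step to lean on. The expectation is a small step in this assay, if any, with the number perhaps drifting slightly upward, and the estimated step of a 1.4-fold higher number from compound 1 to compound 4 (0.15 log units; within the scatter) is taken as lying near the edge of the scatter. Compound 4 is therefore expected to give about 260 nM in this assay, within a range from 90 nM to 750 nM.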

Compound 4, inhibition constant: 655 nM
Beside the measured number, compound 4's estimate is 2.5-fold (0.40 log units) below it; measured number inside the range.
By their numbers in this assay, from the lowest: compounds 3 and 1 (each within the scatter of the next); then compounds 2 and 4 (each within the scatter of the next).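

In this assay, for the compounds shown here, the group on the ring amine nitrogen proves to be a position that responds: quinolin-8-yl in place of naphthalen-1-yl gives a 3.5-fold higher number from compound 1 to compound 4 (0.55 log units; beyond the scatter) with the shared core and the six-carbon chain unchanged, the first step that isolates a change in one place. The two groups have the same count of heavy atoms, and they differ by one ring nitrogen in place of a ring carbon, with one hydrogen-bond acceptor entering, so a change of this limited kind is enough to move the number beyond the scatter. Nothing measured here bears on what lies behind this step.

The compounds shown leave open whether a ring nitrogen elsewhere in the group, as in isoquinolin-5-yl, gives a step of similar size, or whether a simple phenyl or 2-methoxyphenyl group at this place lies nearer to naphthalen-1-yl or to quinolin-8-yl. As far as these compounds go, the step also rests on a single pair, so it remains open whether the same exchange behaves alike with a shorter chain such as butyl or with a different end group on the chain.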